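The compounds below may be only part of what the source reports. "The series", "measured", "known", "first", "only" and "open" are said of these compounds alone.

Of the compounds shown here, three share a common core and have been tested in an ADME assay on L02 cells (Homo sapiens) for inhibition, read by CCK-8 assay, with a stated time of 48 h; on this read-out higher numbers stand for weaker inhibition of growth and lower numbers for stronger inhibition of growth. Compound 1 `Cc1ccccc1Nc1nc(Nc2ccccn2)ncc1Cl` gives 6150 nM, and compound 2 `Cc1ccccc1Nc1nc(Nc2ccc(N3CCCN(C)CC3)cc2)ncc1Cl` gives 1240 nM. Compound 3 `COc1ccccc1CNc1nc(Nc2ccc(N3CCN(C)CC3)cn2)ncc1Cl` gives 25500 nM, the highest of the three numbers, so of the three it inhibits growth of these cells least; its nearest neighbour is compound 1 and the furthest is compound 2, both gaps lying beyond the usual scatter.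

The next compound, compound 4 `Cc1cc(C)c(Nc2nc(Nc3ccc(N4CCN(C)CC4)cn3)ncc2Cl)c(C)c1`, has not yet been measured. It differs from compound 3 in one place: 2,4,6-trimethylphenyl in place of 2-methoxybenzyl on a nitrogen on an aromatic ring.

Going by the values given here, no measured pair shows this exact change, so its effect can only be guessed from the three numbers above. The two compounds with a substituted phenyl directly on that nitrogen, compound 1 and compound 2, both give lower numbers than compound 3. In this assay the step from compound 3 to compound 4 is therefore expected to lower the number by about a 3.2-fold lower number from compound 3 to compound 4 (0.50 log units; beyond the scatter), a modest move towards stronger inhibition of growth. Compound 4 is estimated to give 8000 nM in this assay, with a likely range from 2500 nM to 25000 nM.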

Compound 4, concentration for 50% growth inhibition: 20500 nM
Beside the measured number, compound 4's estimate is 2.6-fold (0.41 log units) below it; the range from low to high includes it.
By their numbers in this assay, from the lowest: compound 2; then compound 1; then compounds 4 and 3 (each within the scatter of the next).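

In this assay, going by these compounds alone, the first direct reading at this position, placing 2,4,6-trimethylphenyl on the nitrogen instead of 2-methoxybenzyl gives a 1.2-fold lower number from compound 3 to compound 4 (0.09 log units; within the scatter). The two groups have the same count of heavy atoms, but only 2-methoxybenzyl has a hydrogen-bond acceptor, and the change from (2-methoxybenzyl)amino to (2,4,6-trimethylphenyl)amino leaves the two compounds indistinguishable on this read-out. Nothing available explains this result.

The compounds shown leave open how this position responds to a group of a different kind, such as a saturated cyclohexyl ring or a chain ending in an amine. Within the data shown here, it also remains open whether the same exchange would read alike with the other parts of the molecule changed, as only this one pair shows it.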